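Aryl Amine Swap on a Shared Core in HeLa Cells

This account rests on a few compounds, and the source may have more. Where it says the series, first, only, none or still open, it means among the compounds named here.

Measured compounds:
compound 1, `CCc1ccc(NC2=CC(=O)c3c(nc4n3[C@H]3OC[C@@H](O)[C@H]3OC4)C2=O)cc1` — 6510 nM
compound 2, `O=C1C=C(Nc2ccc(I)cc2)C(=O)c2c1nc1n2[C@H]2OC[C@@H](O)[C@H]2OC1` — 4070 nM

In a functional assay on HeLa cells (Homo sapiens) for inhibition, read by sulforhodamine B assay (on this read-out higher numbers stand for weaker inhibition and lower numbers for stronger inhibition), compound 1 gives 6510 nM, and compound 2 gives 4070 nM. The gap between the two lies within the usual scatter, so compound 1 sits at essentially the same level as compound 2 on the numbers shown; neither can be called the more potent.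

Compound 3, `O=C1C(Nc2cccc(F)c2)=CC(=O)c2c1nc1n2[C@H]2OC[C@@H](O)[C@H]2OC1`, has not yet been measured in this assay. It differs from compound 1 by 3-fluorophenyl in place of 4-ethylphenyl on an amine nitrogen. Within the data shown here, no step between measured compounds that differ in one place is available to anchor this change, so the expectation rests on the two values alone, which both lie in the low micromolar region.

The step of a 1.3-fold lower number from compound 1 to compound 3 (0.11 log units; within the scatter) is estimated to be small, in either direction, and most likely not beyond the scatter. Compound 3 is therefore expected to give about 5000 nM in this assay, with a range from 1500 nM to 16000 nM.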

Compound 3, half-maximal inhibitory concentration: > 8000 nM
Compound 3: only a limit was reported; the forecaster's own chance of this, stated with the estimate: 10%; middle value at least 1.6-fold (0.20 log units) away from the limit.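

Compound 3 gives > 8000 nM in this assay, which is a limit of the assay and not a number. On the amine nitrogen, 3-fluorophenyl in place of 4-ethylphenyl gives an at least 1.2-fold higher number from compound 1 to compound 3 (0.08 log units; that floor lies within the scatter), so this change brings no gain in inhibition, something compounds 1 and 2 could not show, as both carry a group at the 4-position of the phenyl ring. Since that floor lies within the scatter, the step cannot be called a real loss, and the reading rests on a limit: the limit of > 8000 nM in this assay, at which 1 of the 3 values shown sits.

The compounds shown leave open how far the value of compound 3 lies beyond its limit. They also leave open whether the fluorine or its place on the ring matters, which 4-fluorophenyl or 3-ethylphenyl on the same nitrogen would separate.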